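The source may hold more compounds than are shown below. What is called first, only, known or untested is meant among the compounds shown, and "the series" means these compounds.

Measured compounds and their values:
- compound 1, `Cc1ccc(OCC(=O)N(Cc2cccs2)c2ncco2)cc1`: 0.3 nM
- compound 2, `CCCc1ccc(OCC(=O)N(CC)Cc2cccs2)cc1`: 1810 nM
- compound 3, `Cc1ccc2oc(C(=O)N(Cc3cccs3)c3ccn[nH]3)cc2c1`: 40 nM

All three were tested in an assay on HEK293 cells for agonist activity at transient receptor potential cation channel subfamily M member 8 (Homo sapiens), read by fluorescence and calcium flux, with a stated time of 15 min (on this read-out higher numbers stand for an effect only at larger amounts of compound and lower numbers for an effect already at smaller amounts), which records how much of a compound is needed to reach its defining level of effect. Compound 2 stands at the top of the three: in this assay compound 2 gives 1810 nM, the highest number shown. Compound 3 is the nearest neighbour with 40 nM, and compound 1 is the furthest away with 0.3 nM; both of these gaps lie beyond the usual scatter, so compound 2 is clearly the weakest of the three on this read-out.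

Compound 4, `CCN(Cc1cccs1)C(=O)COc1ccc(OC)cc1`, has not yet been measured. It differs from compound 2 in a single place: methoxy in place of propyl on an aromatic carbon. Among the measured compounds shown here, no pair among the measured compounds shows this change on its own, so there is no directly comparable step to lean on. The step of a 1.5-fold lower number from compound 2 to compound 4 (0.18 log units; within the scatter) is therefore expected to be small, not clearly beyond the scatter in either direction. On that basis compound 4 is estimated at 1200 nM, with a likely range from 300 nM to 5000 nM.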

Compound 4, half-maximal effective concentration: 120 nM
The estimate for compound 4 lay 10-fold (1.00 log units) above the measured number; the whole stated range lies above it.
By their numbers in this assay, from the lowest: compound 1; then compound 3; then compound 4; then compound 2.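

In this assay, the group on this aromatic carbon, para to a large group, clearly matters: methoxy in place of propyl gives a 15-fold lower number from compound 2 to compound 4 (1.18 log units; beyond the scatter), a large step beyond the usual scatter. Among the compounds shown here, the earlier compounds could not show this, as no two of them differed in one place only, so this is the first single change whose size can be read. Methoxy carries an oxygen and a hydrogen-bond acceptor while propyl carries neither, but nothing shown says whether either difference lies behind the step.

As far as these compounds go, whether a hydroxyl group, an amine or a longer chain such as butyl on this carbon would shift the number further remains open. So does whether the same change would give a step of similar size on the core of compound 1.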